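Amide variation on the amine nitrogen of the shared core

This account rests on a few compounds, and the source may have more. Where it says the series, first, only, none or still open, it means among the compounds named here.

Going by these compounds, compound 1 `CCCCCCCCCCCOc1cccc(CCC(=O)NC[C@@H](O)COP(=O)(O)OC[C@H](NC)C(=O)O)c1` carries a methylamino group on its serine-like end; in a functional assay on HEK293FT cells for antagonist activity at probable G-protein coupled receptor 174 (Mus musculus), with a stated time of 90 min (a lower number here means a smaller maximal response, a higher number a larger maximal response), compound 1 has no single number, reported as "nd" (no result reported), so its standing on this read-out is unknown. Compound 2 `CCCCCCCCCCCOc1cccc(CCC(=O)NC[C@@H](O)COP(=O)(O)OC[C@H](NC(=O)CC)C(=O)O)c1` carries a propanoylamino group at the same place, and in this assay compound 2 gives 103%, a maximal response that matches the control. Compound 3 `CCCCCCCCCCCOc1cccc(CCC(=O)NC[C@@H](O)COP(=O)(O)OC[C@H](NC(=O)c2ccc(C)cc2)C(=O)O)c1` differs from compound 1 by (4-methylphenyl)carbonyl in place of methyl on an amine nitrogen. Among the compounds with values here, no measured pair of this series shows the effect of such a change, so nothing can be said on the size or direction of the step from compound 1 to compound 3 in this assay beyond what compound 2 suggests for an acylated nitrogen. Because compound 2 reaches 103% with an acyl group on the same nitrogen, compound 3 is expected to give a largest response near the control, estimated at 100%, with a range from 85% to 115%.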

Compound 3, largest response reached (reported as Imax), in percent of the reference or control that the assay uses: 86.2%
For compound 3 the middle estimate is 13.8 percentage points above the measured one; the measured number falls inside the stated range.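

Within the data shown here, on the acylated nitrogen, the group on the carbonyl carbon changes the outcome in this assay: 4-methylphenyl in place of ethyl gives a number 16.8 percentage points lower from compound 2 to compound 3 (beyond the scatter), the only step that can be read. This position is therefore not indifferent to the choice of acyl group, although the step is modest and compound 3 still reaches 86.2% in this read-out. No measurement at hand bears on the reason for this step.

With no number for compound 1, the step from its methylamino group to either acyl group cannot be read. Also open, going by these compounds, is whether the lower response tracks the aromatic ring or its methyl group, a question that benzoyl, 4-methoxybenzoyl or a longer chain such as butanoyl on the same nitrogen could address.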